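The source may report more compounds than this note shows. Statements on the series, on what has been measured and on what is new or still open speak of the compounds shown alone.

Of the compounds shown here, three of a shared core have been tested in a functional assay on HepG2 cells (Homo sapiens) for cytotoxicity, read by MTT assay, with a stated time of 48 h (a higher number here means a weaker inhibitor, a lower number a stronger inhibitor), so far. Compound 1 `CC(=O)OC[C@H]1O[C@H](NS(=O)(=O)c2ccc(C)cc2)C(OC(C)=O)=C[C@@H]1OC(C)=O` gives 39200000 nM. Compound 2 `CC(=O)OC[C@H]1O[C@H](NS(=O)(=O)c2ccc(C)cc2)C=C[C@@H]1OC(C)=O` gives 157000000 nM, and the step of a 4.0-fold higher number from compound 1 to compound 2 (0.60 log units; beyond the scatter) is the larger of the two measured. Compound 3 `CC(=O)OC[C@H]1O[C@H](NS(=O)(=O)c2ccc(C)cc2)C=C[C@H]1OC(C)=O` gives 307000000 nM, the highest of the three numbers, and the step of a 2.0-fold higher number from compound 2 to compound 3 (0.29 log units; within the scatter) stays within the scatter, which fits (the fact that compounds 2 and 3 differ only in the configuration as drawn).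

Compound 4 `CCS(=O)(=O)N[C@@H]1C=C[C@@H](OC(C)=O)[C@@H](COC(C)=O)O1` differs from compound 3 in a single place: ethyl in place of 4-methylphenyl on a sulfonyl sulfur. Neither measured step touches the sulfonyl substituent; one concerns a ring carbon and the other a configuration, so neither bears on this change directly. Going by the values given here, with no measured step at this position, the expectation for compound 4 in this assay is a step of about a 1.0-fold lower number from compound 3 to compound 4 (0.01 log units; within the scatter), that is, no movement beyond the scatter, and the range is set wide. Compound 4 is therefore estimated at 300000000 nM, between 80000000 nM and 1100000000 nM.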

Compound 4, half-maximal inhibitory concentration: 192000000 nM
The estimate for compound 4 lay 1.6-fold (0.19 log units) above the measured number; the measured number falls inside the stated range.
By their numbers in this assay, from the lowest: compound 1; then compounds 2, 4 and 3 (each within the scatter of the next).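

The sulfonyl sulfur is the place changed here, which neither earlier step touched: in this assay, ethyl in place of 4-methylphenyl gives a 1.6-fold lower number from compound 3 to compound 4 (0.20 log units; within the scatter), so this exchange does not move the number beyond the scatter. For this pair, then, the six-membered aromatic ring of carbon only that leaves is not needed to keep the number at this level. Nothing available bears on why this exchange has so small an effect.

The compounds shown leave open whether a longer chain, or a phenyl ring carrying an amine or a carboxylic acid, on the sulfonyl sulfur would go beyond the scatter. They also leave open whether the same exchange would give a similar step on the core of compound 1, or in the configuration of compound 2.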